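This account rests on a few compounds, and the source may have more. Where it says the series, first, only, none or still open, it means among the compounds named here.

Measured so far in a functional assay on the whole organism (strain Wistar albino) for inhibition, with Rattus norvegicus as the target, read by paw edema, with a stated time of 4 h, at a dose of 70 mg/kg by the oral route; a higher number here means more inhibition at the dose given (going by the name of the read-out), a lower number less inhibition:
compound 1, `CC(C)Cc1ccc(C(C)c2nnc3sc(-c4ccc(Cl)cc4Cl)nn23)cc1`, gives 80.3%;
compound 2, `CC(C)Cc1ccc(C(C)c2nnc3sc(Nc4ccccc4)nn23)cc1`, gives 68.2%.

Compound 2 stands lowest of the two numbers measured in this assay; its nearest neighbour is compound 1, which lies higher by a step beyond the scatter. For the measured compounds named here, the one step known between these compounds is a number 12.1 percentage points lower from compound 1 to compound 2 (beyond the scatter). It concerns the group on the aromatic carbon of the shared core, where an anilino replaces a 2,4-dichlorophenyl; it does not touch the phenyl of the anilino itself.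

Compound 3, `Cc1ccc(Nc2nn3c(C(C)c4ccc(CC(C)C)cc4)nnc3s2)c(C)c1`, differs from compound 2 in exactly that phenyl: 2,4-dimethylphenyl in place of phenyl on a nitrogen on an aromatic ring. Going by the values given here, no measured step alters this phenyl, so the only guide is that compound 1, carrying a ring substituted in the 2,4-positions directly on the core, gave the higher of the two numbers. From this the account expects at most a small rise, one likely to fall within the scatter, for compound 3 in this assay, that is a number 3.8 percentage points higher from compound 2 to compound 3 (within the scatter). The estimate for compound 3 is accordingly 72%, with a range from 58% to 84%.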

Compound 3, a percentage reported as inhibition, in the whole organism at one dose (the size of the read-out at that dose, not a potency): 53%
Compound 3: the middle estimate sits 19 percentage points above what was measured; measured number outside the range, below it.
By their numbers in this assay, from the lowest: compound 3; then compound 2; then compound 1.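

In this assay, the phenyl of the anilino proves sensitive to substitution: 2,4-dimethylphenyl in place of phenyl on the nitrogen gives a number 15.2 percentage points lower from compound 2 to compound 3 (beyond the scatter). The higher number of compound 1 therefore does not extend to every ring substituted at the 2,4-positions, as (2,4-dimethylphenyl)amino in place of 2,4-dichlorophenyl on the aromatic carbon gives a number 27.3 percentage points lower from compound 1 to compound 3 (beyond the scatter), and compound 3 stands lowest of the three. Nothing available accounts for the size of these steps.

The compounds shown leave open whether the fall with 2,4-dimethylphenyl belongs to the methyl groups themselves or to their placement on the ring, and whether a single methyl or a 2,4-dichloro pattern on the anilino ring would give the same result. They also leave open how a methoxy group on that ring, or a saturated amine such as morpholine in place of the anilino, would read at this dose.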